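Compound 3 to compound 4: an estimate of what remains

The compounds below may be only part of what the source reports. "The series", "measured", "known", "first", "only" and "open" are said of these compounds alone.

In an ADME assay on microsomes from liver (Homo sapiens) for metabolic stability, using NADPH, with a stated time of 10 min (a lower number here means that less of the compound is left, a higher number that more of the compound is left), compound 1 `NCCCCN(C[C@H]1Cc2ncccc2CN1)[C@H]1CCCc2cccnc21` gives 100%, compound 2 `CN(CCCCN(C[C@H]1Cc2ncccc2CN1)[C@H]1CCCc2cccnc21)C1CCC(F)(F)CC1` gives 61% and compound 3 `c1cnc2c(c1)CN[C@@H](CN(CCCCNC1CCOCC1)[C@H]1CCCc3cccnc31)C2` gives 97%. Compound 3 therefore sits at the high end of this small set, level with compound 1 and well clear of compound 2.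

Compound 4 `c1cnc2c(c1)CN[C@@H](CN(CCCCN(C1COC1)C1COC1)[C@H]1CCCc3cccnc31)C2` differs from compound 3 at one place: a group of 9 heavy atoms (6 carbon, 1 nitrogen, 2 oxygen; 2 four-membered non-aromatic rings with 1 hetero atom each) in place of a group of 7 heavy atoms (5 carbon, 1 nitrogen, 1 oxygen; one six-membered non-aromatic ring with 1 hetero atom), on a saturated chain carbon, four bonds along the chain from an amine nitrogen.

Within the data shown here, two measured steps bear on this change. One is a number 3 percentage points lower from compound 1 to compound 3 (within the scatter), which shows that a ring holding oxygen was tolerated here. The other is a number 36 percentage points higher from compound 2 to compound 3 (beyond the scatter), a large step showing that the group at this place can matter. Among the measured compounds shown here, the entering group holds oxygen and no fluorine, so it resembles the group in compound 3 more than the one in compound 2, although its two four-membered rings have no measured precedent.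

No step beyond the scatter is expected in this assay, only a slight drop. The estimated step is a number 7 percentage points lower from compound 3 to compound 4 (within the scatter). Compound 4 is expected to give 90%, with an estimated range of 72% to 100%.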

Compound 4, percent of the compound remaining: 62%
The estimate for compound 4 lay 28 percentage points above the measured number; measured number below the stated range.
By their numbers in this assay, from the lowest: compounds 2 and 4 (each within the scatter of the next); then compounds 3 and 1 (each within the scatter of the next).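

In this assay, the change to the two four-membered rings gives a number 35 percentage points lower from compound 3 to compound 4 (beyond the scatter), and the comparison with the unsubstituted amine gives a number 38 percentage points lower from compound 1 to compound 4 (beyond the scatter), so oxygen in the group does not by itself keep the number high. The comparison with the fluorinated cyclohexane group gives a number 1 percentage points higher from compound 2 to compound 4 (within the scatter), which places two very different groups at one level. Among these four compounds, the two lower numbers go with an amine nitrogen on the chain that carries no hydrogen and the two higher numbers with one that does, with no compound against this pattern.

Nothing measured here explains this pattern. The compounds shown leave open whether a single oxetan-3-yl group on that nitrogen, with its hydrogen kept, would behave like oxan-4-yl, and what a methyl group added to that nitrogen in compound 3 would do.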